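A few compounds are considered here, and "the series" means these few. Any claim that something is new, unique, unknown or untested is made for them only; others in the source may bear on it.

Among the compounds with values here, compound 2 `CC(C)(N)C(=O)N[C@H](COCc1ccccc1)c1nnnn1CCC#N` gives the lower of the two numbers so far in a functional assay on H4 cells for agonist activity at growth hormone secretagogue receptor type 1 (Homo sapiens), read by FLIPR (a higher number here means that more compound is needed for the effect, a lower number that less compound is needed), at 30 nM, while compound 1 `CC(C)(N)C(=O)N[C@H](COCc1ccccc1)c1nnnn1CCCCCNS(C)(=O)=O` gives 75 nM. Within the data shown here, the only step known is a 2.5-fold lower number from compound 1 to compound 2 (0.40 log units; beyond the scatter), a swap of the group on the chain attached to the ring nitrogen. Compound 3 `COC(=O)CCCn1nnnc1[C@@H](COCc1ccccc1)NC(=O)C(C)(C)N` carries a different change at the same spot: (methoxycarbonyl)methyl in place of cyano on a saturated chain carbon, two bonds along the chain from an aromatic nitrogen. Among the measured compounds shown here, since the one comparable step was modest, only a small rise in this assay is expected, a 1.7-fold higher number from compound 2 to compound 3 (0.22 log units; within the scatter). For compound 3 the estimate is 50 nM, with a range from 20 nM to 130 nM.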

Compound 3, half-maximal effective concentration: 55 nM
Compound 3: the middle estimate sits 1.1-fold (0.04 log units) below what was measured; the range from low to high includes it.
By their numbers in this assay, from the lowest: compounds 2, 3 and 1 (each within the scatter of the next, the first and the last beyond it).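

At this position in this assay, an ester is accepted on the saturated chain carbon, two bonds along the chain from an aromatic nitrogen: (methoxycarbonyl)methyl in place of cyano gives a 1.8-fold higher number from compound 2 to compound 3 (0.26 log units; within the scatter) and stays level with the nitrile. Methoxycarbonyl in place of 2-(methanesulfonamido)ethyl gives a 1.4-fold lower number from compound 1 to compound 3 (0.13 log units; within the scatter) on the same chain, so compound 3 lies within the scatter of both compounds, although those two differ beyond it. No evidence on the cause bears on this result. Open, as far as these compounds go, is whether a carboxylic acid or an amine at the chain end would fit as well, and whether a longer chain carrying the ester would change the number.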